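A few compounds are considered here, and "the series" means these few. Any claim that something is new, unique, unknown or untested is made for them only; others in the source may bear on it.

Compound 1 `O=S(=O)(Nc1ccc2oc(-c3ccccc3)nc2c1)c1cccc(C(F)(F)F)c1` in an assay on cells for inhibition of HSP60/HSP10 (Homo sapiens), with a stated time of 60 min (a higher number here means a weaker inhibitor, a lower number a stronger inhibitor), gives > 100000 nM, which is a limit of this assay rather than a number (the limit of > 100000 nM in this assay, at which 1 of the 3 values shown sits). Compound 2 `O=S(=O)(Nc1ccc(-c2nc3cc(NS(=O)(=O)c4cccc(O)c4)ccc3o2)cc1)c1cccc(O)c1` gives 17000 nM. Compound 3 `O=S(=O)(Nc1ccc2oc(-c3ccccc3)nc2c1)c1cccc(O)c1` gives 76000 nM.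

Among the two numbers measured in this assay, compound 3 holds the highest; its nearest neighbour is compound 2, the step of a 4.5-fold higher number from compound 2 to compound 3 (0.65 log units; beyond the scatter) coming with hydrogen in place of ((3-hydroxyphenyl)sulfonyl)amino on an aromatic carbon. The other step, an at least 1.3-fold lower number from compound 1 to compound 3 (0.11 log units; that floor lies within the scatter), rests on a limit and sits within the scatter.

Compound 4 `CS(=O)(=O)Nc1ccc2oc(-c3ccccc3)nc2c1`, not yet measured, differs from compound 3 by methyl in place of 3-hydroxyphenyl on a sulfonyl sulfur. Neither measured step alters the group on the sulfonyl sulfur: the step from compound 1 to compound 3 changes only a substituent on that ring and stays within the scatter, while the step from compound 2 to compound 3 shows that losing a whole aryl-sulfonamide arm raises the number modestly. Trimming the aryl to methyl is expected to weaken inhibition by a step of about a 2.0-fold higher number from compound 3 to compound 4 (0.30 log units; within the scatter), with a fair chance that only a limit is reported. For compound 4 the estimate in this assay is 150000 nM, in the range 50000 nM to 500000 nM.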

Compound 4, half-maximal inhibitory concentration: > 100000 nM
Compound 4: a limit, no number; the forecaster's own chance of this, stated with the estimate: 60%; the middle value lies beyond the limit too.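

In this assay compound 4 gives > 100000 nM, which is a limit and not a number. This is the first change shown on the sulfonyl sulfur itself, and an at least 1.3-fold higher number from compound 3 to compound 4 (0.11 log units; that floor lies within the scatter) gives only a floor, so the data do not establish a loss beyond the scatter on replacing 3-hydroxyphenyl with methyl, nor do they set its true size. Compound 4 also adds a second member of the series without a measured number: the limit of > 100000 nM in this assay, at which 2 of the 4 values shown sit.

On these data alone, it remains open whether a longer chain such as n-butyl, or a phenyl carrying an amine or a carboxylic acid, on the sulfonyl sulfur would give a number in this assay. As far as these compounds go, the effect of methyl on the sulfonyl sulfur in the two-armed compound 2 also remains open.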